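A Longer Carbamoyl Chain on Compound 3

The source may hold more compounds than are shown below. What is called first, only, known or untested is meant among the compounds shown, and "the series" means these compounds.

Measured in a functional assay on MOLT-4 cells (Homo sapiens) for inhibition, read by MTT assay, with a stated time of 72 h (on this read-out higher numbers stand for weaker inhibition and lower numbers for stronger inhibition), so far:
- compound 1 `COc1cc(NC(C)CCCNC(=O)Nc2cccc(C(F)(F)F)c2)c2ncccc2c1` gives 20000 nM
- compound 2 `COc1cc(NC(C)CCCNC(=O)NNC(=O)Nc2cccc(C(F)(F)F)c2)c2ncccc2c1` gives 36000 nM
- compound 3 `COc1cc(NC(C)CCCNC(=O)Nc2ccc(Cl)cc2)c2ncccc2c1` gives 24000 nM

Compound 3 lies within the scatter of both compound 1 and compound 2. Compound 4 `COc1cc(NC(C)CCCNC(=O)NNC(=O)Nc2ccc(O)cc2)c2ncccc2c1` carries ((4-hydroxyphenyl)carbamoyl)amino in place of 4-chlorophenyl on an amide-type nitrogen. For the measured compounds named here, one measured step bears on this (a 1.2-fold higher number from compound 1 to compound 3 (0.08 log units; within the scatter)), an exchange of the ring group alone that stayed within the scatter. Going by the values given here, compound 2 (36000 nM) already holds a carbamoyl-amino extension, but no measured compound holds the 4-hydroxyphenyl group. No step beyond the scatter is therefore expected in this assay here, and the higher number is the likelier direction. The estimated step is small (a 1.5-fold higher number from compound 3 to compound 4 (0.18 log units; within the scatter)). Compound 4 is estimated at 36000 nM (expected range 14000 nM to 90000 nM).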

Compound 4, half-maximal inhibitory concentration: 104000 nM
Compound 4: the middle estimate sits 2.9-fold (0.46 log units) below what was measured, and the stated range ends below it.
By their numbers in this assay, from the lowest: compounds 1, 3 and 2 (each within the scatter of the next); then compound 4.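

In this assay, for the compounds shown here, the 4-hydroxyphenyl group brought the first steps beyond the scatter at this amide-type nitrogen (a 4.3-fold higher number from compound 3 to compound 4 (0.64 log units; beyond the scatter); a 5.2-fold higher number from compound 1 to compound 4 (0.72 log units; beyond the scatter)). With the carbamoyl-amino extension present on both sides, exchanging the ring group alone also went beyond the scatter (a 2.9-fold higher number from compound 2 to compound 4 (0.46 log units; beyond the scatter)), unlike the earlier ring exchange without the extension (a 1.2-fold higher number from compound 1 to compound 3 (0.08 log units; within the scatter)). Nothing at hand gives a reason for this shift.

From the compounds shown here alone, how 4-hydroxyphenyl behaves on this nitrogen without the extension stays open. So does whether a 4-methoxyphenyl or 4-aminophenyl group on the extended chain would give a number close to that of compound 4.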